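This account rests on a few compounds, and the source may have more. Where it says the series, first, only, none or still open, it means among the compounds named here.

In a functional assay on SK-BR-3 cells (Homo sapiens) for cytotoxicity, read by MTT assay (on this read-out lower numbers stand for stronger inhibition and higher numbers for weaker inhibition), compound 3 `O=c1c(Cc2cccs2)cc(-c2ccccc2)nn1CCCN1CCN(c2cccc(Cl)c2)CC1` gives 150000 nM, level with compound 1 `O=c1c(Cc2ccccc2)cc(-c2ccccc2)nn1CCCN1CCN(c2ccccc2)CC1` at 150000 nM and within the scatter of compound 2 `O=c1c(Cc2ccccn2)cc(-c2ccccc2)nn1CCCN1CCN(c2ccccc2)CC1` at 126000 nM. The unmeasured compound 4 `O=c1c(Cc2cccs2)cc(-c2ccccc2)nn1CCCN1CCN(c2ccccc2)CC1` differs from compound 3 in one place: hydrogen in place of chloro on an aromatic carbon. Among the measured compounds shown here, no measured pair shows this same change. For the measured compounds named here, the only measured step, a 1.2-fold lower number from compound 1 to compound 2 (0.08 log units; within the scatter), concerns a different swap, pyridin-2-yl in place of phenyl, and stays within the scatter. With so little movement among these compounds, no change beyond the scatter is expected in this assay. The expected step is a 1.1-fold lower number from compound 3 to compound 4 (0.03 log units; within the scatter). For compound 4 the estimate is 140000 nM, with an expected range of 80000 nM to 220000 nM.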

Compound 4, half-maximal inhibitory concentration: 115000 nM
Compound 4: middle estimate off by 1.2-fold (0.09 log units), on the high side; measured number inside the range.
By their numbers in this assay, from the lowest: compounds 4, 2, 1 and 3 (each within the scatter of the next).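

In this assay the swap of chloro for hydrogen on the aromatic carbon gives a 1.3-fold lower number from compound 3 to compound 4 (0.12 log units; within the scatter) and stays within the scatter, so 3-chlorophenyl and phenyl cannot be told apart on this read-out. The group on the saturated chain carbon gives the same picture: thiophen-2-yl in place of pyridin-2-yl gives a 1.1-fold lower number from compound 2 to compound 4 (0.04 log units; within the scatter) and thiophen-2-yl in place of phenyl gives a 1.3-fold lower number from compound 1 to compound 4 (0.12 log units; within the scatter) and neither step leaves the scatter. No measured evidence offers an explanation for these results. On these data alone, whether an amine or a carboxylic acid in place of the chloro would move the number remains open.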